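The compounds below may be only part of what the source reports. "The series", "measured", "known", "first", "only" and "open" are said of these compounds alone.

Compound 1 `O=C(CC1c2ccccc2N=C(SCCCCCN2CCCC2)N1c1ccc(-c2ccccc2)cc1)NCc1ccc(F)cc1` and compound 2 `O=C(CC1c2ccccc2N=C(SCCCCCN2CCCC2)N1c1ccccc1)NCc1ccc(F)cc1` share one core and differ in a single place. Within the data shown here, in a functional assay on A549 cells (Homo sapiens) for cytotoxicity, read by MTT assay, with a stated time of 48 h (a higher number here means a weaker inhibitor, a lower number a stronger inhibitor), compound 1 gives 19800 nM, the lowest of the two numbers so far, and compound 2 gives 89900 nM. The step of a 4.5-fold higher number from compound 1 to compound 2 (0.66 log units; beyond the scatter) arises from hydrogen in place of phenyl on an aromatic carbon. Compound 3 `O=C(CC1c2ccccc2N=C(SCCCCCN2CCCC2)N1c1ccc(-c2ccccc2)cc1)NCc1ccccc1` differs from compound 1 at another site: hydrogen in place of fluoro on an aromatic carbon. Among the measured compounds shown here, none of the measured steps concerns this kind of change; the only step known, from compound 1 to compound 2, alters a different part of the molecule and is of modest size. For the measured compounds named here, with no comparable step to lean on, the expected change in this assay is none beyond the scatter, with at most a slight lean toward a higher number. Compound 3 is therefore estimated at 23000 nM, within 8000 nM to 65000 nM, the expected step being a 1.2-fold higher number from compound 1 to compound 3 (0.07 log units; within the scatter).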

Compound 3, half-maximal inhibitory concentration: 14900 nM
Compound 3: middle estimate off by 1.5-fold (0.19 log units), on the high side, and the stated range covers the measured number.
By their numbers in this assay, from the lowest: compounds 3 and 1 (each within the scatter of the next); then compound 2.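

In this assay, replacing 4-fluorobenzyl with benzyl gives a 1.3-fold lower number from compound 1 to compound 3 (0.12 log units; within the scatter), so the fluoro group on this aromatic carbon can be removed without a change that stands out from the scatter. This site therefore behaves differently from the one probed earlier, where hydrogen in place of phenyl gave a 4.5-fold higher number from compound 1 to compound 2 (0.66 log units; beyond the scatter), although a single swap of fluoro for hydrogen says little about this position as a whole. Nothing at hand explains why the swap leaves the reading within the scatter.

The compounds shown leave open whether a chloro, a methoxy or a carboxylic acid on this same carbon would move the number beyond the scatter. They also leave open whether swapping fluoro for hydrogen would read the same on the core of compound 2.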